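Working notes on cytotoxicity in a small amide series

The compounds below may be only part of what the source reports. "The series", "measured", "known", "first", "only" and "open" are said of these compounds alone.

Measured compounds:
compound 1, `COc1ccc(Br)cc1C(=O)Nc1ccc(Sc2nc3ccccc3s2)cc1`, > 100000 nM
compound 2, `O=C(Nc1ccccc1)c1cc(Br)cc(Br)c1O`, 34000 nM
compound 3, `O=C(Nc1cccc(Cl)c1)c1cccc(Br)c1O`, 32000 nM

In an ADME assay on HEK293 cells (Homo sapiens) for cytotoxicity, read by reporter gene assay and resazurin assay, with a stated time of 48 h (a lower number here means that less compound is tolerated, a higher number that more compound is tolerated), compound 1 gives > 100000 nM, which is a limit of the assay and not a number. Compound 1 therefore sits at the limit of > 100000 nM in this assay, at which 1 of the 3 values shown sits, so its position relative to the other two is known only as a range. In this assay compound 2 gives 34000 nM. In this assay compound 3 gives 32000 nM. Among the measured compounds shown here, compound 2 and compound 3 lie within the scatter of each other, and neither shares a single point of difference with compound 1, so no step between measured compounds can be stated here.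

Compound 4, `COc1c(Br)cccc1C(=O)Nc1ccc(Sc2nc3ccccc3s2)cc1`, has not yet been measured in this assay. It differs from compound 1 as follows: a group of 9 heavy atoms (7 carbon, 1 oxygen, 1 bromine; one six-membered aromatic ring of carbon only) in place of a group of 9 heavy atoms (7 carbon, 1 oxygen, 1 bromine; one six-membered aromatic ring of carbon only), on a carbonyl carbon. The same atoms are present in both; only the arrangement on the aromatic ring changes. For the measured compounds named here, with no measured step as a guide, the expectation is for no step beyond the scatter, and the expected step of a number no higher from compound 1 to compound 4 (the limit leaves the size open) reflects that. Compound 4 is expected to give about 100000 nM in this assay, with a range from 40000 nM to 300000 nM, and a limit value rather than a number is considered likely.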

Compound 4, half-maximal cytotoxic concentration: > 100000 nM
Compound 4: no number, only a limit (the forecaster's own chance of this, stated with the estimate: 70%); the middle value sits exactly at the limit.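

No step can be read between compound 1 and compound 4 in this assay, since both values are limits of the assay and not numbers: the limit of > 100000 nM in this assay, at which 2 of the 4 values shown sit.

The compounds shown leave open how much of either compound is tolerated, and whether the changed arrangement on the aromatic ring alters this at all.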